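Swapping the Chloroindazole for a Pyrazolopyridine in a Diaryl Urea

This account rests on a few compounds, and the source may have more. Where it says the series, first, only, none or still open, it means among the compounds named here.

Two diaryl ureas have been tested in a functional assay on SGC-7901 cells (Homo sapiens) for cytotoxicity, read by MTT assay, with a stated time of 72 h; on this read-out higher numbers stand for weaker inhibition and lower numbers for stronger inhibition. Compound 1 `O=C(Nc1ccc(-n2ncc3c(Cl)cccc32)cc1)Nc1ccc(Cl)c(C(F)(F)F)c1` gives 4600 nM in this assay, the higher of the two numbers, and compound 2 `O=C(Nc1ccc(-n2ncc3c(C(F)(F)F)cccc32)cc1)Nc1ccc(C(F)(F)F)cc1` gives 4000 nM; the two values lie within the scatter of each other, so neither can be called the weaker or the stronger. Compound 3 `O=C(Nc1ccc(-n2ncc3cnccc32)cc1)Nc1ccc(Cl)c(C(F)(F)F)c1` has not been measured. It differs from compound 1 in one place: a group of 9 heavy atoms (6 carbon, 3 nitrogen; one five-membered aromatic ring with 2 hetero atoms, one six-membered aromatic ring with 1 hetero atom) in place of a group of 10 heavy atoms (7 carbon, 2 nitrogen, 1 chlorine; one five-membered aromatic ring with 2 hetero atoms, one six-membered aromatic ring of carbon only), on an aromatic carbon, the new group standing para to a large group on the shared core. Going by the values given here, no measured pair follows this change, so its effect is unknown; a small step in either direction, or none beyond the scatter, would be unsurprising, with a slight lean toward a higher number. Compound 3 is therefore expected to give 6000 nM in this assay, with a range from 2000 nM to 18000 nM. This estimate corresponds to an expected step of a 1.3-fold higher number from compound 1 to compound 3 (0.12 log units; within the scatter).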

Compound 3, half-maximal inhibitory concentration: 22600 nM
Estimate against measurement, compound 3: 3.8-fold (0.58 log units) below, outside the stated range (above it).
By their numbers in this assay, from the lowest: compounds 2 and 1 (each within the scatter of the next); then compound 3.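

In this assay the place on an aromatic carbon, para to a large group, proves sensitive to what stands there: replacing the 4-chloro-1H-indazol-1-yl group with the nitrogen-containing bicyclic group gives a 4.9-fold higher number from compound 1 to compound 3 (0.69 log units; beyond the scatter) and so moves the number beyond the scatter. Compound 1 and compound 2 differ in more than one place and offered no such single-change reading of this position. No measurement shown here explains the step.

The change removes the chlorine and brings a nitrogen into the six-membered ring in one move, so the compounds shown cannot separate the contribution of either. Also open, as far as these compounds go, is whether an amine or a methoxy group in place of the chlorine would keep the number of compound 1 or move it as far as this change did.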